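A few compounds are considered here, and "the series" means these few. Any claim that something is new, unique, unknown or untested is made for them only; others in the source may bear on it.

Measured compounds in a functional assay on UACC-257 cells (Homo sapiens) for cytotoxicity, read by sulforhodamine B assay, with a stated time of 48 h; a lower number here means that less compound is tolerated, a higher number that more compound is tolerated:
- compound 1 `ClCc1cccc(Cn2cnc3ncnc(Cl)c32)c1` gives 18600 nM
- compound 2 `ClCc1ccccc1Cn1cnc2ncnc(Cl)c21` gives 61700 nM
- compound 3 `ClCc1ccc(Cn2cnc3c(Cl)nc(Cl)nc32)cc1` gives 69200 nM

Compound 1 stands lowest of the three numbers in this assay, so it is the compound of which the cells tolerate the least. Compound 2 and compound 3 each lie beyond the usual scatter above compound 1, whereas compound 2 and compound 3 lie within the scatter of each other and are not ordered here.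

The unmeasured compound 4 `ClCc1cccc(Cn2cnc3nc(Cl)nc(Cl)c32)c1` differs from compound 1 in one place: chloro in place of hydrogen on an aromatic carbon. Among the compounds with values here, no pair of measured compounds shows this single change on its own; compound 3 carries a second chloro on the same core but also a differently placed chloromethyl group, so its value gives only a loose pointer. The step expected in this assay is a 1.6-fold higher number from compound 1 to compound 4 (0.21 log units; within the scatter), of modest size and possibly within the scatter. Compound 4 is accordingly estimated at 30000 nM, with a range of 10000 nM to 90000 nM.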

Compound 4, concentration lethal to 50% of the cells: 38900 nM
Estimate against measurement, compound 4: 1.3-fold (0.11 log units) below; measured number inside the range.
By their numbers in this assay, from the lowest: compound 1; then compounds 4, 2 and 3 (each within the scatter of the next).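

In this assay, within the data shown here, chloro in place of hydrogen on the aromatic carbon between two ring nitrogen atoms gives a 2.1-fold higher number from compound 1 to compound 4 (0.32 log units; beyond the scatter), the first change that can be read at a single place. This position therefore responds to substitution, although the step is modest and rests on this one pair, with the change running towards more compound tolerated. Nothing available explains the step.

From the compounds shown here alone, whether an amine or a methoxy group on this same carbon would move the number in the same direction as chloro remains open. Going by these compounds, it is also open whether the step would hold with the chloromethyl group placed differently.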